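The source may hold more compounds than are shown below. What is called first, only, known or untested is meant among the compounds shown, and "the series" means these compounds.

Measured so far:
compound 1 `CCNC(=O)/C=C/c1c(/C=C/c2ccc(OC)cc2)cc(OC)cc1OC` — 7060 nM
compound 2 `CCCCNC(=O)/C=C/c1c(/C=C/c2ccc(OC)cc2)cc(OC)cc1OC` — 1330 nM
compound 3 `COc1ccc(/C=C/c2cc(OC)cc(OC)c2/C=C/C(=O)N2CCCCC2)cc1` — 6050 nM

All three were read in a functional assay on MCF7 cells (Homo sapiens) for inhibition, read by MTT assay, with a stated time of 48 h; on this read-out lower numbers stand for stronger inhibition and higher numbers for weaker inhibition. Compound 1 returns the highest number of the three; compound 3 sits nearest to it, the gap being a 1.2-fold lower number from compound 1 to compound 3 (0.07 log units; within the scatter), while compound 2 sits furthest, at a 5.3-fold lower number from compound 1 to compound 2 (0.72 log units; beyond the scatter). Between the other two the step is a 4.5-fold higher number from compound 2 to compound 3 (0.66 log units; beyond the scatter).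

Compound 4 `COc1ccc(/C=C/c2cc(OC)cc(OC)c2/C=C/C(=O)N2CCCC2)cc1` has not been measured. Relative to compound 1 the change is pyrrolidin-1-yl in place of ethylamino on a carbonyl carbon. The step that bears most directly on it is the one in which the same ethylamino was replaced at the same carbonyl carbon by piperidin-1-yl, likewise a ring, a 1.2-fold lower number from compound 1 to compound 3 (0.07 log units; within the scatter), which stayed within the scatter. Among the compounds with values here, nothing among the measured compounds separates one ring from another at this carbonyl carbon. Within the data shown here, the only step beyond the scatter, a 5.3-fold lower number from compound 1 to compound 2 (0.72 log units; beyond the scatter), concerns lengthening an open chain and does not bear on a ring in this place. The expectation is therefore no step beyond the scatter, a 1.2-fold lower number from compound 1 to compound 4 (0.07 log units; within the scatter). For compound 4 the estimate in this assay is 6000 nM, with a range from 2500 nM to 14000 nM.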

Compound 4, half-maximal inhibitory concentration: 4200 nM
Compound 4: the middle estimate sits 1.4-fold (0.15 log units) above what was measured, within the range that was stated.
By their numbers in this assay, from the lowest: compound 2; then compounds 4, 3 and 1 (each within the scatter of the next).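

In this assay, the second ring at this carbonyl carbon also stays close to the open ethylamino group, a 1.7-fold lower number from compound 1 to compound 4 (0.23 log units; within the scatter), and the one-five-membered-ring change from piperidin-1-yl to pyrrolidin-1-yl gives no separation either, a 1.4-fold lower number from compound 3 to compound 4 (0.16 log units; within the scatter), so ring size across these two rings does not register here, and the two compounds lacking the amide hydrogen both read level with compound 1, which keeps it. Butylamino now stands apart from a further amide at this place, a 3.2-fold higher number from compound 2 to compound 4 (0.50 log units; beyond the scatter), which leaves compound 2 as the only compound of the four whose steps to all the others lie beyond the scatter, and so the one with the strongest inhibition in this set. No measurement shown here accounts for either the level readings among the rings or the separate position of butylamino.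

Still open, from the compounds shown here alone, is whether a ring with a second hetero atom, such as morpholin-4-yl or piperazin-1-yl, would stay level with these two rings. Also open, going by these compounds, is whether an open chain longer than butylamino, such as hexylamino, would extend the step seen for compound 2 or reverse it.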